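Aryl group change from compound 1 to compound 3

The source may hold more compounds than are shown below. What is called first, only, known or untested is meant among the compounds shown, and "the series" means these compounds.

Measured so far:
- compound 1 `CN1CCN(CCCOc2cccc3nc(Nc4ccc(Cl)c(C(F)(F)F)c4)ccc23)CC1` gives 4180 nM in the growth read-out
- compound 2 `CN1CCN(CCCOc2cccc3nc(Nc4ccc(Cl)c(F)c4)ccc23)CC1` gives 4870 nM in the growth read-out

Both values come from a functional assay on cells (Panel ovarian (Carcinoma cell lines), Homo sapiens) for inhibition, read by sulforhodamine B assay, with a stated time of 48 h (on this read-out higher numbers stand for weaker inhibition of growth and lower numbers for stronger inhibition of growth), and sit within the scatter of each other, so compound 1 stands level with compound 2 and holds no separate place on these numbers.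

Moving to compound 3 `CN1CCN(CCCOc2cccc3nc(Nc4ccc(F)c(F)c4)ccc23)CC1` means 3,4-difluorophenyl in place of 4-chloro-3-(trifluoromethyl)phenyl on a nitrogen on an aromatic ring on the shared core. Within the data shown here, one measured step bears on this change: a 1.2-fold higher number from compound 1 to compound 2 (0.07 log units; within the scatter) with fluoro in place of trifluoromethyl on an aromatic carbon, and it lies within the scatter. Among the measured compounds shown here, no measured step covers the loss of the chlorine, which leaves that part of the change open. No shift beyond the scatter is therefore expected in either direction in this assay on present evidence. The expected step is a 1.2-fold higher number from compound 1 to compound 3 (0.08 log units; within the scatter) and this estimate stays within the scatter. Compound 3 is estimated at 5000 nM with an expected range from 3000 nM to 8500 nM as the working figure.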

Compound 3, concentration for total growth inhibition: 10800 nM
Estimate against measurement, compound 3: 2.2-fold (0.33 log units) below; the measured number lies above the stated range.
By their numbers in this assay, from the lowest: compounds 1 and 2 (each within the scatter of the next); then compound 3.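

In this assay the chloro group carries weight on this aryl ring: fluoro in place of chloro on an aromatic carbon gives a 2.2-fold higher number from compound 2 to compound 3 (0.35 log units; beyond the scatter), whereas the earlier exchange of trifluoromethyl for fluoro stayed within the scatter. The whole exchange of 4-chloro-3-(trifluoromethyl)phenyl for 3,4-difluorophenyl on the nitrogen gives a 2.6-fold higher number from compound 1 to compound 3 (0.41 log units; beyond the scatter), so among these three compounds the two aryl groups that keep chloro stand level and the one without it gives weaker inhibition of growth. Nothing available explains why this exchange raises the number.

Going by these compounds, whether bromo, methyl or methoxy in place of the chloro would hold the number near that of compound 2 remains open. So does the effect of an amine or a carboxylic acid on the same aryl ring.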